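The source may hold more compounds than are shown below. What is called first, only, known or untested is meant among the compounds shown, and "the series" means these compounds.

In a functional assay on CWR22R cells (Homo sapiens) for antiproliferative activity, read by propidium iodide staining, with a stated time of 96 h (on this read-out higher numbers stand for weaker inhibition and lower numbers for stronger inhibition), compound 1 `CC(O)(CSc1ccc(F)cc1)C(=O)Nc1ccc(S(F)(F)(F)(F)F)cc1` gives 13500 nM and compound 2 `CC(O)(CSc1ccc(C(F)(F)F)cc1)C(=O)Nc1ccc(S(F)(F)(F)(F)F)cc1` gives 14800 nM, so the two stand level within the scatter. Compound 3 `CC(O)(COc1ccc(C#N)cc1)C(=O)Nc1ccc(S(F)(F)(F)(F)F)cc1` has 4-cyanophenoxy in place of (4-fluorophenyl)sulfanyl on a saturated chain carbon, two bonds along the chain from a carbonyl carbon and an oxygen on a saturated carbon. Among the measured compounds shown here, the only measured step, a 1.1-fold higher number from compound 1 to compound 2 (0.04 log units; within the scatter), exchanges fluoro for trifluoromethyl on an aromatic carbon and stays within the scatter. For the measured compounds named here, no measured pair tests an exchange of sulfanyl for phenoxy, so this step bears on the change only weakly. No shift beyond the scatter is expected, though with wide uncertainty. The expected step is a 1.1-fold lower number from compound 1 to compound 3 (0.05 log units; within the scatter). Compound 3 is estimated at 12000 nM, with an expected range of 4000 nM to 35000 nM.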

Compound 3, half-maximal inhibitory concentration: 26100 nM
Beside the measured number, compound 3's estimate is 2.2-fold (0.34 log units) below it; low and high end bracket the measured number.
By their numbers in this assay, from the lowest: compounds 1, 2 and 3 (each within the scatter of the next).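

On a saturated chain carbon, two bonds along the chain from a carbonyl carbon and an oxygen on a saturated carbon, 4-cyanophenoxy in place of (4-fluorophenyl)sulfanyl gives a 1.9-fold higher number from compound 1 to compound 3 (0.29 log units; within the scatter) in this assay, so this place accepts a change of linking atom and ring substituent together without a shift beyond the scatter. No supporting evidence bears on this result.

The compounds shown do not separate the oxygen-for-sulfur exchange from the nitrile-for-fluoro exchange, which 4-fluorophenoxy would do. From the compounds shown here alone, an amine on this chain carbon also remains open.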